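From 4-fluorophenyl to 4-chlorophenyl in the series

A few compounds are considered here, and "the series" means these few. Any claim that something is new, unique, unknown or untested is made for them only; others in the source may bear on it.

In a functional assay on MIA PaCa-2 cells (Homo sapiens) for antiproliferative activity, read by sulforhodamine B assay, with a stated time of 48 h (a higher number here means a weaker inhibitor of growth, a lower number a stronger inhibitor of growth), compound 1 `COc1ccc(Cn2cc(CNC(=O)c3cn(-c4ccccc4)nc3-c3ccc(F)cc3)nn2)cc1OC` gives > 100000 nM, which is a limit and not a number. Within the data shown here, compound 2 `COc1cc(Cn2cc(CNC(=O)c3cn(-c4ccccc4)nc3-c3ccc(F)cc3)nn2)cc(OC)c1OC` gives 5200 nM, the only actual number so far. Compound 3 `COc1cc(Cn2cc(CNC(=O)c3cn(-c4ccccc4)nc3-c3ccc(Cl)cc3)nn2)cc(OC)c1OC` differs from compound 2 by chloro in place of fluoro on an aromatic carbon, with chloro in place of fluoro on an aromatic carbon, para to a large group. Among the measured compounds shown here, the sole measured step, an at least 19-fold lower number from compound 1 to compound 2 (1.28 log units; beyond the scatter), is large, but it is methoxy in place of hydrogen and gives no direct size for this swap. The expected 1.2-fold lower number from compound 2 to compound 3 (0.06 log units; within the scatter) stays within the scatter, with no direction favoured. For compound 3 the estimated value is 4500 nM, with an expected range of 1500 nM to 15000 nM.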

Compound 3, concentration for 50% growth inhibition: 3500 nM
Beside the measured number, compound 3's estimate is 1.3-fold (0.11 log units) above it; the measured number falls inside the stated range.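

In this assay, among these compounds, the change from 4-fluorophenyl to 4-chlorophenyl gives a 1.5-fold lower number from compound 2 to compound 3 (0.17 log units; within the scatter), the first reading at this position on the aromatic carbon para to a large group. Chloro and fluoro are therefore not separated here, and the earlier methoxy step says nothing about this site. Nothing available bears on a cause for this result. Whether an amine, a nitrile or a carboxylic acid at this position would move the number beyond the scatter stays open, since only two halogens are shown there.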